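Hydroxy in Place of Hydrogen: From Compound 3 to Compound 4

The compounds below may be only part of what the source reports. "The series", "measured", "known", "first", "only" and "open" are said of these compounds alone.

Compound 1 `NCc1csc(NC(=O)c2ccc(Cl)cc2)n1`: 25 ug/mL
Compound 2 `NCc1csc(NC(=O)c2ccn[nH]2)n1`: > 100 ug/mL (a limit)
Compound 3 `Cc1csc(NC(=O)c2cc(C(C)(C)C)nn2Cc2ccccc2)n1`: < 1.6 ug/mL (a limit)

In a physicochemical assay for solubility, read by nephelometry, measured as kinetic solubility, at pH 6.5 (a higher number here means a more soluble compound, a lower number a less soluble compound), compound 1 gives 25 ug/mL. Compound 2 returns only a limit, > 100 ug/mL, which is the limit of > 100 ug/mL in this assay, at which 1 of the 3 values shown sits. Compound 3 likewise returns only a limit, < 1.6 ug/mL, and this is the limit of < 1.6 ug/mL in this assay, at which 1 of the 3 values shown sits, so compound 3 stands at the bottom of the three values, with no number of its own. Compound 4 `CC(C)(C)c1cc(C(=O)Nc2nc(CO)cs2)n(Cc2ccccc2)n1` differs from compound 3 in a single place: hydroxy in place of hydrogen on a saturated chain carbon bound to an aromatic carbon. Among the compounds with values here, no two measured compounds differ in only one place, so no measured step is available to guide the expectation; it rests on the structural change alone. The step is expected to go upward in this assay, by about an at least 2.5-fold higher number from compound 3 to compound 4 (0.39 log units; beyond the scatter), with a real chance that the result is again reported as a limit rather than a number. Compound 4 is therefore estimated at 4 ug/mL, within a range from 1.6 ug/mL to 15 ug/mL.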

Compound 4, solubility: 3.1 ug/mL
The estimate for compound 4 lay 1.3-fold (0.11 log units) above the measured number; low and high end bracket the measured number.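

In this assay, the change from methyl to hydroxymethyl reads as an at least 1.9-fold higher number from compound 3 to compound 4 (0.28 log units; that floor lies within the scatter), so the data give only a floor for this step and not its size. Compound 4 gives a measured number, 3.1 ug/mL, and is the first compound shown with this change in place. Compound 3 gives only a limit, so the true size of the step stays unknown because of that limit: the limit of < 1.6 ug/mL in this assay, at which 1 of the 4 values shown sits.

The compounds shown leave open whether the hydroxy group changes the reading by more than the scatter, since compound 3 has no number of its own. They also leave open how a carboxylic acid, a methoxy group or a longer chain such as hydroxyethyl would read in place of the hydroxymethyl on this same core.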